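A Sulfamoyl in Place of a Carbamoyl

A few compounds are considered here, and "the series" means these few. Any claim that something is new, unique, unknown or untested is made for them only; others in the source may bear on it.

Compound 1 `Cn1c(=O)c(C(=O)Nc2ccc(F)cc2F)cc2cnc(Nc3ccc4[nH]ccc4c3)nc21`: 5000 nM
Compound 2 `Cn1c(=O)c(S(=O)(=O)c2ccc(F)cc2F)cc2cnc(Nc3ccncn3)nc21`: 30000 nM
Compound 3 `Cc1ccc(S(=O)(=O)c2cc3cnc(Nc4ccc5cc[nH]c5c4)nc3n(C)c2=O)cc1`: 15000 nM

In a functional assay on K562 cells (Homo sapiens) for inhibition, read by trypan blue exclusion, with a stated time of 72 h (on this read-out higher numbers stand for weaker inhibition and lower numbers for stronger inhibition), compound 1 gives 5000 nM as the lowest of the three numbers. Compound 3 at 15000 nM and compound 2 at 30000 nM both stand higher, and both gaps lie beyond the scatter, so compound 1 is the strongest inhibitor of the three.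

Compound 4 `Cn1c(=O)c(S(=O)(=O)Nc2ccc(F)cc2)cc2cnc(Nc3ccc4[nH]ccc4c3)nc21` has not yet been measured. It keeps the core of compound 1 and carries (4-fluorophenyl)sulfamoyl in place of (2,4-difluorophenyl)carbamoyl on an aromatic carbon while the rest of the molecule stays the same.

For the measured compounds named here, no two measured compounds differ in one place only, so the data give no direct measure of this change. Compound 1 already holds the lowest number, and compound 3 at 15000 nM is the nearest one above it, so an upward move is the likelier direction. The expected change is a 1.8-fold higher number from compound 1 to compound 4 (0.26 log units; within the scatter) and would be a step of about the size of the scatter toward weaker inhibition. Compound 4 is expected at 9000 nM with an estimated range from 3000 nM to 27000 nM in this assay once it is measured.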

Compound 4, half-maximal inhibitory concentration: 5000 nM
Compound 4: the middle estimate sits 1.8-fold (0.26 log units) above what was measured, and the stated range covers the measured number.
By their numbers in this assay, from the lowest: compounds 1 and 4 (each within the scatter of the next); then compounds 3 and 2 (each within the scatter of the next).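

For the compounds shown here, putting (4-fluorophenyl)sulfamoyl in place of (2,4-difluorophenyl)carbamoyl on this aromatic carbon gives no change at the digits printed from compound 1 to compound 4 (within the scatter) in this assay, a direct reading at this position that the earlier compounds, none of which differed from another in one place only, could not give. The position thus accepts an exchange that keeps the count of heavy atoms and the single six-membered aromatic ring of carbon only, yet alters the linking atoms, adds a hydrogen-bond acceptor and leaves one fluorine where there were two, all with no change in the number beyond the scatter. Nothing measured here bears on why the two groups read alike.

The step changes the link and the fluorine pattern together, so the compounds shown do not separate the part played by each; a (2,4-difluorophenyl)sulfamoyl or a (4-fluorophenyl)carbamoyl group would be needed to pull them apart. They also leave open how far this acceptance extends at this carbon, for instance to a carboxylic acid, a simple amine or a sulfamoyl carrying an alkyl chain instead of the aromatic ring.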